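The source may report more compounds than this note shows. Statements on the series, on what has been measured and on what is new or still open speak of the compounds shown alone.

In a functional assay on RPMI-8226 cells (Homo sapiens) for inhibition, read by MTT assay, with a stated time of 72 h (a lower number here means a stronger inhibitor, a higher number a weaker inhibitor), compound 1 `CC1(C)CCC(CN2CCN(c3ccc(C(=O)NS(=O)(=O)c4ccc(NCCCCCC(=O)NO)c([N+](=O)[O-])c4)c(Oc4cnc5[nH]ccc5c4)c3)CC2)=C(c2ccc(Cl)cc2)C1` gives 300 nM and compound 2 `CC1(C)CCC(CN2CCN(c3ccc(C(=O)NS(=O)(=O)c4ccc(NCCCCCCC(=O)NO)c([N+](=O)[O-])c4)c(Oc4cnc5[nH]ccc5c4)c3)CC2)=C(c2ccc(Cl)cc2)C1` gives 300 nM, so compound 2 stands level with compound 1. Compound 3 `CC1(C)CCC(CN2CCN(c3ccc(C(=O)NS(=O)(=O)c4ccc(NCCCCCCCC(=O)NO)c([N+](=O)[O-])c4)c(Oc4cnc5[nH]ccc5c4)c3)CC2)=C(c2ccc(Cl)cc2)C1` repeats the same kind of change: (hydroxycarbamoyl)methyl in place of hydroxycarbamoyl on a saturated chain carbon, six bonds along the chain from a nitrogen on an aromatic ring, with (hydroxycarbamoyl)methyl in place of hydroxycarbamoyl on a saturated chain carbon, six bonds along the chain from a nitrogen on an aromatic ring. Among the measured compounds shown here, the one measured step of this kind, no change at the digits printed from compound 1 to compound 2 (within the scatter), stayed within the scatter, so no shift beyond the scatter is expected in this assay, and no direction can be named. The expected step is no change at the digits printed from compound 2 to compound 3 (within the scatter). The estimated value for compound 3 is 300 nM, with an expected range of 130 nM to 700 nM.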

Compound 3, half-maximal inhibitory concentration: 200 nM
The estimate for compound 3 lay 1.5-fold (0.18 log units) above the measured number; the measured number falls inside the stated range.
By their numbers in this assay, from the lowest: compounds 3, 1 and 2 (each within the scatter of the next).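

In this assay, extending the chain that ends in the hydroxycarbamoyl group once more gives a 1.5-fold lower number from compound 2 to compound 3 (0.18 log units; within the scatter), and the two extensions taken together give a 1.5-fold lower number from compound 1 to compound 3 (0.18 log units; within the scatter). Even across both extensions the numbers stay within the scatter, so this assay does not separate these three chain lengths. Nothing measured here offers a reason for this. Still open, on these data alone, is whether a longer chain would keep the number level, and whether a carboxylic acid in place of the hydroxycarbamoyl end would move it.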